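From Compound 2 to a Methylthiophene Relative

This account rests on a few compounds, and the source may have more. Where it says the series, first, only, none or still open, it means among the compounds named here.

In an ADME assay on HEK293 cells (Homo sapiens) for cytotoxicity, read by MTT assay, with a stated time of 48 h (a higher number here means a weaker inhibitor, a lower number a stronger inhibitor), compound 1 (`CC(C)c1ccc(/C=C2/S/C(=N/c3ccccc3)N(Cc3ccncc3)C2=O)cc1`) gives 137000 nM and compound 2 (`COc1cc(/C=C2/S/C(=N/c3ccccc3)N(Cc3ccncc3)C2=O)ccc1O`) gives 67400 nM as the lower of the two numbers. The two differ only in the group on a double-bonded chain carbon bound to a double-bonded ring carbon. Compound 3 (`Cc1ccc(/C=C2/S/C(=N/c3ccccc3)N(Cc3ccncc3)C2=O)s1`) changes that same place, with 5-methylthiophen-2-yl in place of 4-hydroxy-3-methoxyphenyl (5-methylthiophen-2-yl in place of 4-hydroxy-3-methoxyphenyl on a double-bonded chain carbon bound to a double-bonded ring carbon). Within the data shown here, only one measured step bears on this swap (a 2.0-fold lower number from compound 1 to compound 2 (0.31 log units; beyond the scatter)), and it was modest. Among the measured compounds shown here, compound 3 gives up the group that came with the lower number in that step, so a move of no greater size toward a higher number is expected, though this new ring has no measured precedent here. The expected step is a 1.6-fold higher number from compound 2 to compound 3 (0.19 log units; within the scatter) in this assay and remains an estimate. Compound 3 is estimated at 105000 nM with 50000 nM to 220000 nM as its expected range.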

Compound 3, half-maximal inhibitory concentration: 146000 nM
For compound 3 the middle estimate is 1.4-fold (0.14 log units) below the measured one; the range from low to high includes it.
By their numbers in this assay, from the lowest: compound 2; then compounds 1 and 3 (each within the scatter of the next).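

In this assay, the swap gives a 2.2-fold higher number from compound 2 to compound 3 (0.34 log units; beyond the scatter), so the lower number of compound 2 does not carry over to this sulfur-containing five-membered ring. Among these compounds, the second comparison, a 1.1-fold higher number from compound 1 to compound 3 (0.03 log units; within the scatter), shows that the 5-methylthiophen-2-yl and 4-isopropylphenyl groups cannot be told apart here, which leaves 4-hydroxy-3-methoxyphenyl as the only one of the three groups at this place that stands apart, and only by a modest step. No supporting measurement is available to explain this result.

The compounds shown leave open which part of the 4-hydroxy-3-methoxyphenyl group goes with the lower number, since its hydroxyl and methoxy groups never appear separately on the ring. They also leave open how an amine or a carboxylic acid on the ring at this place would compare.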